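Piperidin-1-yl in place of pyrrolidin-1-yl in compound 2

The source may hold more compounds than are shown below. What is called first, only, known or untested is meant among the compounds shown, and "the series" means these compounds.

Measured in a functional assay on A549 cells (Homo sapiens) for inhibition, with a stated time of 72 h; on this read-out higher numbers stand for weaker inhibition and lower numbers for stronger inhibition:
Compound 1 `O=C(Nc1ccccc1)Nc1nc(NC2CC2)cc(Sc2c[nH]c3ccccc23)n1`: > 50000 nM, a limit of the assay
Compound 2 `O=C(Nc1ccccc1)Nc1nc(Sc2c[nH]c3ccccc23)cc(N2CCCC2)n1`: 21200 nM
Compound 3 `Cc1cc(Cl)ccc1NC(=O)Nc1nc(Sc2c[nH]c3ccccc23)cc(N2CCCC2)n1`: 8930 nM

Of the two actual numbers in this assay, compound 2 holds the higher, at 21200 nM. Among the compounds with values here, its only numerical neighbour is compound 3, reached by a 2.4-fold lower number from compound 2 to compound 3 (0.38 log units; beyond the scatter). Compound 1 gives only a limit, > 50000 nM.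

Compound 4 `O=C(Nc1ccccc1)Nc1nc(Sc2c[nH]c3ccccc23)cc(N2CCCCC2)n1` has not yet been measured. It differs from compound 2 at one place, with piperidin-1-yl in place of pyrrolidin-1-yl on an aromatic carbon.

Within the data shown here, two measured steps bear on this change. The closer one is an at least 2.3-fold lower number from compound 1 to compound 2 (0.37 log units; beyond the scatter), made at the same place, where pyrrolidin-1-yl replaced cyclopropylamino. One end of that step is a limit, so it gives only a bound on its size. The other is a 2.4-fold lower number from compound 2 to compound 3 (0.38 log units; beyond the scatter), made elsewhere, on an amide-type nitrogen. Neither step swaps one non-aromatic ring for another, so neither gives a direction for this change. The expected result is therefore a 1.1-fold lower number from compound 2 to compound 4 (0.03 log units; within the scatter), with no shift beyond the scatter anticipated. For compound 4 the estimated value is 20000 nM, with an expected range of 9000 nM to 45000 nM.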

Compound 4, half-maximal inhibitory concentration: 33100 nM
Compound 4: the middle estimate sits 1.7-fold (0.22 log units) below what was measured; measured number inside the range.
By their numbers in this assay, from the lowest: compound 3; then compounds 2 and 4 (each within the scatter of the next). At a limit, above all of these: compound 1.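

In this assay, swapping one non-aromatic ring for another at this position, the five-membered pyrrolidin-1-yl for the six-membered piperidin-1-yl, gives a 1.6-fold higher number from compound 2 to compound 4 (0.19 log units; within the scatter), so the two rings are not separated on this read-out. Against cyclopropylamino at the same place, piperidin-1-yl gives an at least 1.5-fold lower number from compound 1 to compound 4 (0.17 log units; that floor lies within the scatter), whereas pyrrolidin-1-yl gives an at least 2.3-fold lower number from compound 1 to compound 2 (0.37 log units; beyond the scatter), which clears the scatter even as a floor. Compound 1 stands at a limit of the assay, so both comparisons with it give a floor and not a size: the limit of > 50000 nM in this assay, at which 1 of the 4 values shown sits.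

Still open, going by these compounds, is whether a morpholine ring or an open-chain dimethylamino group at this position would stay within the scatter of compound 2 and compound 4 or move away from them. Also open, on these data alone, is whether the 4-chloro-2-methylphenyl group, which separates compound 3 from compound 2, would have a similar effect on the amide-type nitrogen of compound 4, where piperidin-1-yl takes the place of pyrrolidin-1-yl.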